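The compounds below may be only part of what the source reports. "The series", "measured", "known", "first", "only" and "open" are said of these compounds alone.

Compound 1 `CCCCCCCCNc1ccc([N+](=O)[O-])cc1S(N)(=O)=O`: < 0.0834 h, a limit
Compound 2 `CN(C)S(=O)(=O)c1cc(C(=O)O)ccc1NCCCC(F)(F)F`: > 1 h, a limit
Compound 3 `CN(C)S(=O)(=O)c1cc(C(=O)O)c(Cl)cc1NCCCCCCCC(F)(F)F`: > 1 h, a limit

All three results in an ADME assay on microsomes from liver (Mus musculus) for metabolic stability, tested at 5 uM (on this read-out higher numbers stand for a longer-lived compound and lower numbers for a shorter-lived compound), are limits and not exact numbers. Compound 3 stands at the limit of > 1 h in this assay, at which 2 of the 3 values shown sit.

Compound 4 `COc1cc(NCCCCCCCC(F)(F)F)c(S(=O)(=O)N(C)C)cc1C(=O)O` has not yet been measured. It carries methoxy in place of chloro on an aromatic carbon, ortho to a carboxy group and para to a dimethylsulfamoyl group (methoxy in place of chloro on an aromatic carbon).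

Within the data shown here, no measured pair shows this change, so the expected step that the limit leaves unreadable from compound 3 to compound 4 is none beyond the scatter, in either direction. This expectation rests on compound 3, whose > 1 h is a limit. For compound 4 the estimated half-life is 1.2 h, with an expected range from 0.5 h to 3 h.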

Compound 4, half-life in the Mus musculus assay: > 1 h
Compound 4: no number, only a limit (the forecaster's own chance of this, stated with the estimate: 65%); the middle value lies beyond the limit too.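

In the Mus musculus assay compound 3 gives only a limit, > 1 h. In the Mus musculus assay compound 4 also gives only a limit, > 1 h. Among these compounds, no step between them can be read. On these data alone, whether methoxy in place of chloro on an aromatic carbon changes the half-life at all stays open. In a physicochemical assay for solubility, in phosphate buffer, measured as kinetic solubility, at pH 7.4, tested at 250 uM (on this read-out higher numbers stand for higher solubility and lower numbers for lower solubility), compound 3 gives 241000 nM and compound 4 gives 188000 nM. In the physicochemical assay the step reads a 1.3-fold lower number from compound 3 to compound 4 (0.11 log units; within the scatter).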